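Isopentyl for 1,1-dimethylpropyl on the cyanoguanidine nitrogen

The source may report more compounds than this note shows. Statements on the series, on what has been measured and on what is new or still open speak of the compounds shown alone.

This account follows a series of cyanoguanidines tested in a functional assay (aorta) with Rattus norvegicus as the target; a lower number here means a stronger inhibitor, a higher number a weaker inhibitor. Compound 1 `CCC(C)(C)/N=C(\NC#N)Nc1cc(C(F)(F)F)cc(C(F)(F)F)c1` gives 900 nM in this assay, the lowest number among the three measured compounds. For the measured compounds named here, compound 3 `C[C@H](/N=C(\NC#N)Nc1cc(Cl)cc(Cl)c1)c1ccccc1` gives 30000 nM, a number well beyond the scatter of the one for compound 1. Compound 2 `N#CN/C(=N\C1CCCC1)Nc1cc(Cl)cc(Cl)c1` gives 75000 nM, the highest of the three. Compounds 2 and 3 carry a different substitution pattern on the aryl ring from compound 1, so the gap to them cannot be attributed to any single change.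

Compound 4 `CC(C)CC/N=C(\NC#N)Nc1cc(C(F)(F)F)cc(C(F)(F)F)c1` has not yet been measured in this assay. It differs from compound 1 in one place: isopentyl in place of 1,1-dimethylpropyl on a double-bonded nitrogen. Going by the values given here, both groups are the same size and neither contributes donors or acceptors; the only change is the branching of the chain at the double-bonded nitrogen.

Among the compounds with values here, nothing among the measured compounds shows what this particular change does. Since the two groups match in size and polarity, a modest shift is expected, most likely toward a somewhat higher number, giving an expected step of a 2.8-fold higher number from compound 1 to compound 4 (0.44 log units; beyond the scatter). Compound 4 is therefore estimated to give 2500 nM in this assay, with a likely range from 800 nM to 8000 nM.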

Compound 4, half-maximal inhibitory concentration: 5600 nM
Estimate against measurement, compound 4: 2.2-fold (0.35 log units) below; measured number inside the range.
By their numbers in this assay, from the lowest: compound 1; then compound 4; then compound 3; then compound 2.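

Exchanging 1,1-dimethylpropyl for isopentyl on the double-bonded nitrogen is not a neutral swap in this assay: the change gives a 6.2-fold higher number from compound 1 to compound 4 (0.79 log units; beyond the scatter). This reveals a sensitivity that compounds 2 and 3 could not show, as neither differs from compound 1 in one place only. The two groups match in heavy atoms, carbon count, donors, acceptors and charge, so this position distinguishes between two chains that differ only in how their atoms are joined, and in this single pair the lower number belongs to 1,1-dimethylpropyl. No measurement here bears on what lies behind this difference.

The compounds shown leave open whether a straight pentyl chain, a tert-butyl group or a neopentyl group would stay close to compound 1 or fall nearer to compound 4. They also leave open whether the same exchange would have a similar effect in the chlorine-bearing series of compounds 2 and 3, or whether it holds only on the core of compound 1.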